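The source may report more compounds than this note shows. Statements on the series, on what has been measured and on what is new or still open speak of the compounds shown alone.

Measured so far:
compound 1 `CCC(=O)N1N=C(c2ccc(C)cc2)CC1c1cn(-c2ccccc2)nc1-c1ccc(Cl)c(Cl)c1`: 61.1%
compound 2 `CC(=O)N1N=C(c2ccc(C)cc2)CC1c1cn(-c2ccccc2)nc1-c1ccc(Cl)c(Cl)c1`: 59.5%

Both numbers come from a functional assay on the whole organism (strain Wistar) for inhibition, with Rattus norvegicus as the target, read by paw edema, with stated times of 30 min and 60 min, at a dose of 50 mg/kg by the oral route; a higher number here means more inhibition at the dose given (going by the name of the read-out), a lower number less inhibition. Among the measured compounds shown here, compound 2 stands lowest of the two, with compound 1 nearest; the only measured step, a number 1.6 percentage points lower from compound 1 to compound 2 (within the scatter), lies within the scatter. Compound 3 `Cc1ccc(C2=NNC(c3cn(-c4ccccc4)nc3-c3ccc(Cl)c(Cl)c3)C2)cc1` differs from compound 2 by hydrogen in place of acetyl on an amine nitrogen in a ring. For the measured compounds named here, no measured step removes the whole acyl group from the ring nitrogen, so that one step bears only loosely: shortening the chain on the carbonyl carbon changed nothing beyond the scatter. The expected step is a number 5.5 percentage points lower from compound 2 to compound 3 (within the scatter), kept small because a number 1.6 percentage points lower from compound 1 to compound 2 (within the scatter) lies within the scatter, but with a widened range given the lack of a direct precedent. Compound 3 is estimated at 54%, between 38% and 68%.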

Compound 3, a percentage reported as inhibition, in the whole organism at one dose (the size of the read-out at that dose, not a potency): 56.5%
Estimate against measurement, compound 3: 2.5 percentage points below; low and high end bracket the measured number.
By their numbers in this assay, from the lowest: compounds 3, 2 and 1 (each within the scatter of the next).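

In this assay, hydrogen in place of acetyl on the amine nitrogen in the ring gives a number 3 percentage points lower from compound 2 to compound 3 (within the scatter), and hydrogen in place of propanoyl gives a number 4.6 percentage points lower from compound 1 to compound 3 (within the scatter). The earlier step only shortened the chain on the carbonyl carbon; these steps show that losing the whole acyl group from this nitrogen leaves the inhibition at this dose within the scatter. No measurement at hand bears on the reason for this result.

Open, as far as these compounds go, is whether a benzoyl group, a longer acyl chain or an alkyl group on this nitrogen would move the number beyond the scatter.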